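Compound 2 to compound 3: one phenyl group exchanged

This account rests on a few compounds, and the source may have more. Where it says the series, first, only, none or still open, it means among the compounds named here.

Compound 1 `COc1cc2ncnc(Nc3ccc(F)c(Cl)c3)c2cc1NC(=O)N/N=C/c1ccc(F)cc1Cl`: 25700 nM
Compound 2 `COc1cc2ncnc(Nc3ccc(F)c(Cl)c3)c2cc1NC(=O)N/N=C/c1cc(Br)c(O)c(Br)c1`: 41500 nM

Both values come from a functional assay on PC-3 cells (Homo sapiens) for cytotoxicity, read by MTT assay, with a stated time of 72 h (a lower number here means a stronger inhibitor, a higher number a weaker inhibitor), and compound 2 lies within the scatter of compound 1. Compound 3 `COc1cc2ncnc(Nc3ccc(F)c(Cl)c3)c2cc1NC(=O)N/N=C/c1ccc(O)cc1O` differs from compound 2 on a carbon with a double bond to nitrogen: 2,4-dihydroxyphenyl in place of 3,5-dibromo-4-hydroxyphenyl on a carbon with a double bond to nitrogen. For the measured compounds named here, the only measured step at this place, a 1.6-fold higher number from compound 1 to compound 2 (0.21 log units; within the scatter), exchanged one substituted phenyl for another and stayed within the scatter. Going by the values given here, no measured compound carries 2,4-dihydroxyphenyl. In this assay, therefore, no change beyond the scatter is expected, and the estimated step is a 1.4-fold lower number from compound 2 to compound 3 (0.14 log units; within the scatter). For compound 3 the estimated value is 30000 nM, with an expected range from 12000 nM to 70000 nM.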

Compound 3, half-maximal inhibitory concentration: 29500 nM
Estimate against measurement, compound 3: 1.0-fold (0.01 log units) above; the range from low to high includes it.
By their numbers in this assay, from the lowest: compounds 1, 3 and 2 (each within the scatter of the next).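

In this assay, 2,4-dihydroxyphenyl on a carbon with a double bond to nitrogen gives a 1.4-fold lower number from compound 2 to compound 3 (0.15 log units; within the scatter), and against 2-chloro-4-fluorophenyl it gives a 1.1-fold higher number from compound 1 to compound 3 (0.06 log units; within the scatter). A third substituted phenyl, this one with hydroxyl groups and no halogen, therefore stays within the scatter of both earlier compounds, so all three steps at this place lie within it. Nothing measured explains why these numbers lie so close together. The compounds shown leave open whether a phenyl bearing an amine or a carboxylic acid, or a longer alkyl chain in place of the phenyl, would move the number beyond the scatter.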